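Nitro replaced by sulfamoyl on the phenyl arm

A few compounds are considered here, and "the series" means these few. Any claim that something is new, unique, unknown or untested is made for them only; others in the source may bear on it.

Compound 3 `N#CC1=C(N)Oc2c(c3nc4ccccc4nc3c3ccccc23)C12C(=O)N(Cc1cnnn1-c1ccc([N+](=O)[O-])cc1)c1ccccc12` gives only a limit in a functional assay on MCF7 cells (Homo sapiens) for antiproliferative activity, read by MTT assay, with a stated time of 48 h; a lower number here means a stronger inhibitor, a higher number a weaker inhibitor: the value > 50000 nM is a limit of the assay and not a number. Compound 1 `COc1ccccc1-n1nncc1CN1C(=O)C2(C(C#N)=C(N)Oc3c2c2nc4ccccc4nc2c2ccccc32)c2ccccc21` likewise gives the limit > 50000 nM in this assay. Compound 2 `CCOc1ccc(-n2nncc2CN2C(=O)C3(C(C#N)=C(N)Oc4c3c3nc5ccccc5nc3c3ccccc43)c3ccccc32)cc1` gives the limit > 50000 nM in this assay. Because of the limit of > 50000 nM in this assay, at which 3 of the 3 values shown sit, the steps a step that the two limits leave unreadable from compound 1 to compound 2, a step that the two limits leave unreadable from compound 1 to compound 3 and a step that the two limits leave unreadable from compound 2 to compound 3 cannot be read in size or direction. Compound 4 `N#CC1=C(N)Oc2c(c3nc4ccccc4nc3c3ccccc23)C12C(=O)N(Cc1cnnn1-c1cccc(S(N)(=O)=O)c1)c1ccccc12` differs from compound 3 by 3-sulfamoylphenyl in place of 4-nitrophenyl on an aromatic nitrogen. Going by the values given here, no measured step bears on this change, since every value shown is a limit. Compound 4 is therefore expected to remain at the limit as well, the step that the limit leaves unreadable from compound 3 to compound 4 meaning no change that the assay could register. The estimate for compound 4 in this assay is 60000 nM, between 20000 nM and 200000 nM.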

Compound 4, half-maximal inhibitory concentration: 42500 nM
Beside the measured number, compound 4's estimate is 1.4-fold (0.15 log units) above it; measured number inside the range.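

Compound 4 is the only compound shown that gives a number rather than a limit in this assay, so 3-sulfamoylphenyl on this aromatic nitrogen brings the series into the readable range. The steps to it are an at least 1.1-fold lower number from compound 3 to compound 4 (0.07 log units; that floor lies within the scatter), an at least 1.1-fold lower number from compound 2 to compound 4 (0.07 log units; that floor lies within the scatter) and an at least 1.1-fold lower number from compound 1 to compound 4 (0.07 log units; that floor lies within the scatter), so no gain beyond the scatter is shown. These floors give no true size, and the steps among compound 1, compound 2 and compound 3 still cannot be read, because of one shared limit: the limit of > 50000 nM in this assay, at which 3 of the 4 values shown sit.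

Going by these compounds, whether the sulfamoyl group itself or its ring position matters stays open. So does how an amine or a carboxylic acid on the phenyl arm would read.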